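From 3-fluorophenyl to 4-methylphenyl

This account rests on a few compounds, and the source may have more. Where it says the series, first, only, none or still open, it means among the compounds named here.

Measured in a functional assay on HeLa cells (Homo sapiens) for antiproliferative activity, read by MTT assay, with a stated time of 72 h; a lower number here means a stronger inhibitor, a higher number a weaker inhibitor:
- compound 1 `CCNC(=O)c1cc(Oc2ccc(NC(=O)c3nn(-c4ccc(Br)cc4F)c(=O)cc3C)cc2)ccn1`: "not active" (no number reported)
- compound 2 `CCNC(=O)c1cc(Oc2ccc(NC(=O)c3nn(-c4cccc(F)c4)c(=O)cc3C)cc2)ccn1`: 6870 nM

Among the compounds with values here, compound 2 is the only compound with a number, 6870 nM, so it cannot yet be ranked against another value. Compound 3 `CCNC(=O)c1cc(Oc2ccc(NC(=O)c3nn(-c4ccc(C)cc4)c(=O)cc3C)cc2)ccn1` differs from it as follows: 4-methylphenyl in place of 3-fluorophenyl on an aromatic nitrogen. Within the data shown here, no measured pair shows what this swap does, so no step beyond the scatter is expected in this assay, in either direction. Compound 1, at "not active" (no number reported), shows that a result without a number is also possible. The expected change is a 1.1-fold lower number from compound 2 to compound 3 (0.06 log units; within the scatter). For compound 3 the estimated value is 6000 nM, with an expected range of 1800 nM to 25000 nM.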

Compound 3, half-maximal inhibitory concentration: 10700 nM
The estimate for compound 3 lay 1.8-fold (0.25 log units) below the measured number; low and high end bracket the measured number.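

Measured in this assay the exchange of 3-fluorophenyl for 4-methylphenyl on the aromatic nitrogen gives a 1.6-fold higher number from compound 2 to compound 3 (0.19 log units; within the scatter) and so the two compounds cannot be told apart. At this position, an aromatic ring carrying a fluorine and one carrying a methyl group thus give numbers that repeat measurements could not separate. Nothing available explains this result.

Within the data shown here, this single pair covers only two small groups on that ring. From the compounds shown here alone, whether an amine, a carboxylic acid or a longer chain there would give a step beyond the scatter remains open.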